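The compounds below may be only part of what the source reports. "The series", "measured", "known", "first", "only" and "open" are said of these compounds alone.

Compound 1 `N=C(N)c1ccc(-c2ccc(-c3ccc(F)cc3)o2)o1` gives 1760 nM in a functional assay on NCI-H460 cells (Homo sapiens) for inhibition, read by sulforhodamine B assay, with a stated time of 48 h (a higher number here means a weaker inhibitor of growth, a lower number a stronger inhibitor of growth), and compound 2 `N=C(N)c1ccc(-c2ccc(-c3ccc4ccccc4c3)s2)s1` gives 1950 nM in this assay; the two numbers lie within the scatter of each other, so neither compound can be set apart on this assay. Compound 3 `COc1ccc(-c2ccc(-c3ccc(C(=N)N)o3)o2)cc1` is not yet measured in this assay. It differs from compound 1 by methoxy in place of fluoro on an aromatic carbon. Among the measured compounds shown here, no measured pair shows what this exchange does, so no step beyond the scatter is expected in either direction. Compound 3 is therefore estimated at 1600 nM, with a likely range from 600 nM to 4500 nM. That estimate means a step of a 1.1-fold lower number from compound 1 to compound 3 (0.04 log units; within the scatter).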

Compound 3, concentration for 50% growth inhibition: 1170 nM
Compound 3: middle estimate off by 1.4-fold (0.14 log units), on the high side, within the range that was stated.
By their numbers in this assay, from the lowest: compounds 3, 1 and 2 (each within the scatter of the next).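

In this assay, methoxy in place of fluoro on an aromatic carbon, para to a large group, gives a 1.5-fold lower number from compound 1 to compound 3 (0.18 log units; within the scatter). This first pair at this position shows that the larger group, which also brings a hydrogen-bond acceptor, leaves the number within the scatter of compound 1. No measurement here offers an explanation for this result. From the compounds shown here alone, whether an amine, a carboxylic acid or a longer chain such as butoxy at this position would also stay within the scatter of compound 1 remains open.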